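This account rests on a few compounds, and the source may have more. Where it says the series, first, only, none or still open, it means among the compounds named here.

Series notes, amide side chains and the group on the double-bonded chain carbon. In a functional assay on PC-3 cells (Homo sapiens) for inhibition, read by CellTiter-Glo, with a stated time of 72 h (on this read-out higher numbers stand for lower toxicity in this test and lower numbers for higher toxicity in this test), compound 1 `CC1=C(CC(=O)NCCN(C)C)c2cc(F)ccc2/C1=C\c1nc2ccccc2s1` gives 4880 nM and compound 2 `CC1=C(CC(=O)N(C)CCN(C)C)c2cc(F)ccc2/C1=C\c1nc2ccccc2s1` gives 5880 nM. Among the compounds with values here, the only measured step, a 1.2-fold higher number from compound 1 to compound 2 (0.08 log units; within the scatter), swaps a methyl for the amide hydrogen and stays within the scatter.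

Compound 3 `CC1=C(CC(=O)N2CCN(CCCN(C)C)CC2)c2cc(F)ccc2/C1=C\c1ccc([S+](C)[O-])cc1` gives > 50000 nM, which is a limit of the assay and not a number.

Compound 4 `CC1=C(CC(=O)N2CCN(CCCN(C)C)CC2)c2cc(F)ccc2/C1=C\c1nc2ccccc2s1` keeps the amide side chain of compound 3 and differs from it at one place: a group of 9 heavy atoms (7 carbon, 1 nitrogen, 1 sulfur; one five-membered aromatic ring with 2 hetero atoms, one six-membered aromatic ring of carbon only) in place of a group of 9 heavy atoms (7 carbon, 1 oxygen, 1 sulfur; one six-membered aromatic ring of carbon only), on a double-bonded chain carbon bound to a double-bonded ring carbon. Within the data shown here, no measured step covers this exchange, and none covers the change of side chain between the pairs. The closest guide is indirect: compound 1, at 4880 nM, already carries the 1,3-benzothiazol-2-yl group, and so does compound 2, at 5880 nM. Their side chains differ from that of compound 4, so the range is kept wide, and a reading near the limit cannot be excluded.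

The step expected in this assay is an at least 7.1-fold lower number from compound 3 to compound 4 (0.85 log units; beyond the scatter), in the direction of lower numbers and higher toxicity. For compound 4 the estimated value is 7000 nM, with an expected range of 2000 nM to 30000 nM.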

Compound 4, half-maximal cytotoxic concentration: 4210 nM
Estimate against measurement, compound 4: 1.7-fold (0.22 log units) above; measured number inside the range.
By their numbers in this assay, from the lowest: compounds 4, 1 and 2 (each within the scatter of the next). At a limit, above all of these: compound 3.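

With the amide side chain held fixed, 1,3-benzothiazol-2-yl in place of the group of compound 3, on a double-bonded chain carbon bound to a double-bonded ring carbon, gives in this assay an at least 11-fold lower number from compound 3 to compound 4 (1.07 log units; beyond the scatter), so a change at this place alone moves the read-out towards higher toxicity in this test. That size is only a floor, because compound 3 stands at a limit and not at a number: the limit of > 50000 nM in this assay, at which 1 of the 4 values shown sits.
With 1,3-benzothiazol-2-yl kept, the change of side chain gives a 1.4-fold lower number from compound 2 to compound 4 (0.15 log units; within the scatter) and a 1.2-fold lower number from compound 1 to compound 4 (0.06 log units; within the scatter), both within the scatter, so among these three compounds the amide side chains show no readable difference.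

On these data alone, it remains open whether the exchange at the chain carbon gives a step of similar size with the (2-(dimethylamino)ethyl)amino side chain, and how a plain phenyl or a benzoxazol-2-yl group would read at that place. The compounds shown also leave open how a side chain ending in a carboxylic acid or a morpholine would read with 1,3-benzothiazol-2-yl in place.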